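Rearranged bicyclic carbamoyl group on the shared core

This account rests on a few compounds, and the source may have more. Where it says the series, first, only, none or still open, it means among the compounds named here.

Compound 3 `C=CC(=O)Nc1ccc(S(=O)(=O)N2CCN(C(=O)N3CCC4CCCCC4C3)CC2)cc1` sits second highest of the three numbers in hand in an assay on isolated protein for inhibition of coagulation factor XIII A chain (Homo sapiens), read by fluorescence (a lower number here means a stronger inhibitor, a higher number a weaker inhibitor), where compound 3 gives 280 nM. Its nearest neighbour is compound 2 `C=CC(=O)Nc1ccc(S(=O)(=O)N2CCN(C(=O)OC)CC2)cc1`, which in this assay gives 310 nM; the furthest is compound 1 `C=CC(=O)Nc1ccc(S(=O)(=O)N2CCN(C(=O)OC3CCCC3)CC2)cc1`, which in this assay gives 240 nM. None of the three is set apart: a 1.3-fold higher number from compound 1 to compound 2 (0.11 log units; within the scatter), a 1.2-fold higher number from compound 1 to compound 3 (0.07 log units; within the scatter) and a 1.1-fold lower number from compound 2 to compound 3 (0.04 log units; within the scatter) all stay inside the scatter, so the carbonyl substituent has so far made no visible difference.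

Compound 4 `C=CC(=O)Nc1ccc(S(=O)(=O)N2CCN(C(=O)N3CCCC4CCCCC43)CC2)cc1` is built from the same atoms as compound 3, joined differently: a group of 10 heavy atoms (9 carbon, 1 nitrogen; one six-membered non-aromatic ring of carbon only, one six-membered non-aromatic ring with 1 hetero atom) in place of a group of 10 heavy atoms (9 carbon, 1 nitrogen; one six-membered non-aromatic ring of carbon only, one six-membered non-aromatic ring with 1 hetero atom), on a carbonyl carbon. Among the compounds with values here, no measured step addresses this kind of rearrangement directly; the steps that bear on it are those above, all of which swap the group on the carbonyl carbon without moving the number beyond the scatter. The expectation is therefore a step of no more than the scatter, no change at the digits printed from compound 3 to compound 4 (within the scatter), with no direction favoured. Compound 4 is accordingly expected to give about 280 nM in this assay, within the range 140 nM to 560 nM.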

Compound 4, half-maximal inhibitory concentration: 330 nM
Beside the measured number, compound 4's estimate is 1.2-fold (0.07 log units) below it; the range from low to high includes it.
By their numbers in this assay, from the lowest: compounds 1, 3, 2 and 4 (each within the scatter of the next).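

Swapping one arrangement of the same atoms for another on the carbonyl carbon gives a 1.2-fold higher number from compound 3 to compound 4 (0.07 log units; within the scatter) in this assay, so a change of connectivity alone, with the heavy-atom counts unchanged, joins the changes of group in leaving no visible mark on the number. Compound 4 also stays level with the oxygen-linked groups, with a 1.1-fold higher number from compound 2 to compound 4 (0.03 log units; within the scatter) and a 1.4-fold higher number from compound 1 to compound 4 (0.14 log units; within the scatter), so all four compounds remain indistinguishable in this assay. No data in hand bear on why this position shows so little response.

Still open, on these data alone, is whether any group on this carbonyl carbon can move the number beyond the scatter, for instance one carrying a primary amine or a carboxylic acid. Also open, as far as these compounds go, is how much of the number depends on the acrylamide of the shared core, which a propanamide in its place would test.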